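This account rests on a few compounds, and the source may have more. Where it says the series, first, only, none or still open, it means among the compounds named here.

Measured so far:
- compound 1 `CCC(=O)C1=C(O)C(C)(C)C(O)=C(Cc2c(O)c3c(c(C(C)=O)c2O)OC(C)(C)C=C3)C1=O`: in a functional assay on cells (Melanoma cell, Homo sapiens) for cytotoxicity, with a stated time of 72 h (on this read-out higher numbers stand for an effect only at larger amounts of compound and lower numbers for an effect already at smaller amounts), compound 1 gives 5 ug/mL
- compound 2 `CCC(=O)C1=C(O)C(C)(C)C(O)=C(Cc2c(O)c3c(c(C(=O)CC)c2O)OC(C)(C)C=C3)C1=O`: in this assay compound 2 gives 8 ug/mL

Among the measured compounds shown here, compound 1 has the lower of the two numbers, and its only neighbour is compound 2, with a 1.6-fold higher number from compound 1 to compound 2 (0.20 log units; within the scatter). Compound 3 `CC(=O)C1=C(O)C(C)(C)C(O)=C(Cc2c(O)c3c(c(C(C)=O)c2O)OC(C)(C)C=C3)C1=O` differs from compound 1 by hydrogen in place of methyl on a saturated chain carbon bound to a carbonyl carbon. For the measured compounds named here, the one measured step, a change of the same kind in the other direction, stayed within the scatter, so no step beyond the scatter is expected here: for compound 3 the expected step is no change at the digits printed from compound 1 to compound 3 (within the scatter). Compound 3 is therefore estimated at 5 ug/mL, with a range from 2.5 ug/mL to 12 ug/mL.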

Compound 3, concentration for half-maximal effect: 12 ug/mL
Beside the measured number, compound 3's estimate is 2.4-fold (0.38 log units) below it, and the stated range covers the measured number.
By their numbers in this assay, from the lowest: compounds 1, 2 and 3 (each within the scatter of the next, the first and the last beyond it).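

In this assay the change from propanoyl to acetyl gives a 2.4-fold higher number from compound 1 to compound 3 (0.38 log units; beyond the scatter) and so shows that removing one methyl at this position can move the number beyond the scatter, if only modestly. The same kind of change at the other carbonyl gave a 1.6-fold higher number from compound 1 to compound 2 (0.20 log units; within the scatter) and showed no such shift. Nothing available here accounts for this step.

Going by these compounds, whether a longer chain such as butanoyl, or an amine on this carbonyl carbon, would raise or lower the number remains open.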